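A five-membered ring exchanged on compound 2

A few compounds are considered here, and "the series" means these few. Any claim that something is new, unique, unknown or untested is made for them only; others in the source may bear on it.

In an ADME assay on the whole organism (Mus musculus, strain CD1), with a stated time of 24 h, at a dose of 10 mg/kg by the oral route (a lower number here means less compound in the circulation, a higher number more compound in the circulation at the dose given), compound 2 (`CC(C)c1noc(-c2cccc(CNc3ccc4[nH]nc(C(=O)O)c4c3)c2O)n1`) gives 181 ng.h/mL, the lower of the two numbers available. Compound 1 (`CN(C)c1noc(-c2cccc(CN(C)c3ccc4[nH]nc(C(=O)O)c4c3)c2O)n1`) gives 2780 ng.h/mL, a gap beyond the scatter, but the two compounds differ in more than one place, so this gap cannot be tied to any single change. Compound 3 (`Cc1nc(-c2cccc(CNc3ccc4[nH]nc(C(=O)O)c4c3)c2O)sc1C`) has not yet been measured. It carries 4,5-dimethyl-1,3-thiazol-2-yl in place of 3-isopropyl-1,2,4-oxadiazol-5-yl on an aromatic carbon, ortho to a hydroxy group: 4,5-dimethyl-1,3-thiazol-2-yl in place of 3-isopropyl-1,2,4-oxadiazol-5-yl on an aromatic carbon. For the measured compounds named here, no measured pair tests this exchange, so the expectation is a loose one, anchored on compound 2 at 181 ng.h/mL. No step beyond the scatter is expected in this assay. The estimated step is a 1.7-fold higher number from compound 2 to compound 3 (0.22 log units; within the scatter). For compound 3 the estimated value is 300 ng.h/mL, with an expected range from 80 ng.h/mL to 1200 ng.h/mL.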

Compound 3, area under the concentration-time curve: 18200 ng.h/mL
Compound 3: the middle estimate sits 61-fold (1.78 log units) below what was measured, and the stated range ends below it.
By their numbers in this assay, from the lowest: compound 2; then compound 1; then compound 3.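

In this assay, putting 4,5-dimethyl-1,3-thiazol-2-yl in place of 3-isopropyl-1,2,4-oxadiazol-5-yl, on the aromatic carbon ortho to a hydroxy group, gives a 100-fold higher number from compound 2 to compound 3 (2.00 log units; beyond the scatter). For the compounds shown here, this is the first change that can be read at a single place, and it shows that the five-membered ring at this position alone can move the number far beyond the scatter while the rest of compound 2 stays the same. Nothing measured here explains the size of this step.

The exchange alters the ring's hetero atoms and its alkyl substituents together, so the compounds shown do not separate the contribution of the sulfur from that of the two methyl groups. Also open, on these data alone, is how a thiazole carrying a single isopropyl group or an amine at this position would read, and whether the exchange gives a similar step on the core of compound 1.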